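Aryl-ring variation on a fatty-acid amide hydrolase inhibitor series

The source may hold more compounds than are shown below. What is called first, only, known or untested is meant among the compounds shown, and "the series" means these compounds.

Measured compounds:
Compound 1, `COc1ccc(-c2cnc(C(=O)CCCCCCc3ccccc3)o2)cc1`, 100 nM
Compound 2, `Cc1cccnc1-c1cnc(C(=O)CCCCCCc2ccccc2)o1`, 15 nM
Compound 3, `Cc1cccc(-c2cnc(C(=O)CCCCCCc3ccccc3)o2)n1`, 3.3 nM

All three compounds were tested in an assay (Rattus norvegicus) for inhibition of Fatty-acid amide hydrolase 1 (Homo sapiens); on this read-out higher numbers stand for weaker inhibition and lower numbers for stronger inhibition. Compound 3 stands lowest of the three numbers; the nearest is compound 2, with a 4.5-fold lower number from compound 2 to compound 3 (0.66 log units; beyond the scatter), and the furthest is compound 1, with a 30-fold lower number from compound 1 to compound 3 (1.48 log units; beyond the scatter). The change from compound 1 to compound 2 was also beyond the scatter: a 6.7-fold lower number from compound 1 to compound 2 (0.82 log units; beyond the scatter).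

Compound 4, `O=C(CCCCCCc1ccccc1)c1ncc(-c2cncnc2)o1`, is not yet measured. It differs from compound 3 in one place: pyrimidin-5-yl in place of 6-methylpyridin-2-yl on an aromatic carbon. Among the compounds with values here, none of the measured steps makes this exact exchange, but all three bear on it, since they show that the aromatic group at this position moves the numbers strongly, with the two methyl-bearing pyridinyl groups giving the lowest numbers and the 4-methoxyphenyl the highest. Pyrimidin-5-yl carries no methyl and a different arrangement of ring nitrogens, so the large gain seen from compound 1 to compound 3 is not expected to be fully kept. Compound 4 is therefore expected to give a higher number than compound 3, estimated as 40 nM with a range from 8 nM to 200 nM. This means an expected step of a 12-fold higher number from compound 3 to compound 4 (1.08 log units; beyond the scatter).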

Compound 4, inhibition constant: 22 nM
Compound 4: middle estimate off by 1.8-fold (0.26 log units), on the high side; the range from low to high includes it.
By their numbers in this assay, from the lowest: compound 3; then compounds 2 and 4 (each within the scatter of the next); then compound 1.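

Within this assay, the pyrimidin-5-yl group shows that this place on the shared core does not need a methyl-bearing ring to improve on the 4-methoxyphenyl group: the exchange gives a 4.5-fold lower number from compound 1 to compound 4 (0.66 log units; beyond the scatter) and does so with a ring that has 2 hetero atoms and no methyl. The same group does not match the 6-methylpyridin-2-yl group, since the exchange gives a 6.7-fold higher number from compound 3 to compound 4 (0.82 log units; beyond the scatter) and so sets compound 3 apart from a second ring type, not only from the 3-methylpyridin-2-yl group of compound 2. Against that 3-methylpyridin-2-yl group, the exchange gives a 1.5-fold higher number from compound 2 to compound 4 (0.17 log units; within the scatter) and leaves the two groups unresolved in this assay, even though they differ in ring nitrogens and in the methyl.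

Still open, going by these compounds, is how a plain pyridin-2-yl group, with no methyl, or a 6-aminopyridin-2-yl group would stand here, which would help separate the part played by the methyl from that of the ring nitrogen. Nothing available accounts for the differences among these aromatic groups.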